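Replacing 2,6-dimethoxyphenyl with 2,4-dichlorophenyl in a growth-inhibition series

The source may report more compounds than this note shows. Statements on the series, on what has been measured and on what is new or still open speak of the compounds shown alone.

Three compounds sharing one core and differing in the aryl group on a carbon with a double bond to nitrogen have been measured in a functional assay on MDA-MB-231 cells (Homo sapiens) for inhibition, read by sulforhodamine B assay, with a stated time of 48 h; on this read-out higher numbers stand for weaker inhibition of growth and lower numbers for stronger inhibition of growth. Compound 1 `O=C(Cc1csc2nc(-c3ccc(Br)cc3)cn12)N/N=C/c1ccccc1O`, with 2-hydroxyphenyl, gives 17000 nM. Compound 2 `O=C(Cc1csc2nc(-c3ccc(Br)cc3)cn12)N/N=C/c1ccc(O)cc1`, with 4-hydroxyphenyl, gives 43700 nM. Compound 3 `COc1cccc(OC)c1/C=N/NC(=O)Cc1csc2nc(-c3ccc(Br)cc3)cn12`, with 2,6-dimethoxyphenyl, gives 40700 nM. The step of a 1.1-fold lower number from compound 2 to compound 3 (0.03 log units; within the scatter) lies within the scatter, so these two read alike. The modest steps of a 2.6-fold higher number from compound 1 to compound 2 (0.41 log units; beyond the scatter) and a 2.4-fold higher number from compound 1 to compound 3 (0.38 log units; beyond the scatter) lie beyond it, leaving compound 1 alone at the lowest number.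

Compound 4 `O=C(Cc1csc2nc(-c3ccc(Br)cc3)cn12)N/N=C/c1ccc(Cl)cc1Cl` has 2,4-dichlorophenyl in place of 2,6-dimethoxyphenyl on a carbon with a double bond to nitrogen. Among the compounds with values here, no measured compound carries chlorine, so no step shows this change directly. The nearest guides are the three exchanges of this same group, and even the largest, a 2.6-fold higher number from compound 1 to compound 2 (0.41 log units; beyond the scatter), is modest. No step beyond the scatter is therefore expected in this assay, and no direction can be firmly called. The expected move is a 1.3-fold lower number from compound 3 to compound 4 (0.10 log units; within the scatter). Compound 4 is estimated at 32000 nM, with an expected range of 13000 nM to 75000 nM.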

Compound 4, concentration for total growth inhibition: > 100000 nM
Compound 4: no number, only a limit (the forecaster's own chance of this, stated with the estimate: 10%); at least 3.1-fold (0.49 log units) between middle value and limit.
By their numbers in this assay, from the lowest: compound 1; then compounds 3 and 2 (each within the scatter of the next). At a limit, above all of these: compound 4.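

In this assay compound 4 gives no number, only a limit of the assay: the limit of > 100000 nM in this assay, at which 1 of the 4 values shown sits.

Even so, all three new steps can be read as lying beyond the scatter: an at least 2.4-fold higher number from compound 3 to compound 4 (0.39 log units; beyond the scatter), an at least 2.2-fold higher number from compound 2 to compound 4 (0.35 log units; beyond the scatter) and an at least 5.8-fold higher number from compound 1 to compound 4 (0.76 log units; beyond the scatter). Within the data shown here, this position had so far held only groups carrying oxygen, and 2,4-dichlorophenyl, which carries chlorine and no hydrogen-bond acceptors, shows that a change here can take the read-out past all three earlier compounds, towards weaker inhibition of growth, and not only by the modest steps seen among them.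

The compounds shown do not separate the arrival of chlorine from the departure of oxygen, and they do not tell how far compound 4 lies past its limit. Also open, on these data alone, is how a phenyl ring with a single chlorine, an amine or a carboxylic acid on a carbon with a double bond to nitrogen would read, and whether any such group would come closer to compound 1 or go beyond it.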